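Spiro core amides: ester side chain to sulfonamide amide

The compounds below may be only part of what the source reports. "The series", "measured", "known", "first", "only" and "open" are said of these compounds alone.

Measured compounds:
compound 1 `CC1(C)CC(OC(=O)CN2CN(c3ccccc3)C3(CCN(C(=O)c4ccc(C(C)(C)C)cc4)CC3)C2=O)CC(C)(C)N1` gives 1300 nM in an assay on HEK293 cells for displacement of a labelled ligand from NPC1-like intracellular cholesterol transporter 1 (Homo sapiens); a higher number here means a weaker inhibitor, a lower number a stronger inhibitor
compound 2 `CCc1nn(CC)c(C2CCN(C(=O)CN3CN(c4ccccc4)C4(CCN(C(=O)c5ccc(C6CCCCC6)cc5)CC4)C3=O)CC2)c1C` gives "not determined" (no result reported) in this assay

Among the measured compounds shown here, compound 1 carries the only number in the set; compound 2 gives nothing to compare against, so compound 1 stands alone and no step between measured compounds can be drawn from these data.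

Compound 3 `CC(C)(C)c1ccc(C(=O)N2CCC3(CC2)C(=O)N(CC(=O)NCCCNS(C)(=O)=O)CN3c2ccccc2)cc1` keeps the core of compound 1 and changes the ester end of the side chain: (3-(methanesulfonamido)propyl)amino in place of (2,2,6,6-tetramethylpiperidin-4-yl)oxy on a carbonyl carbon. The (2,2,6,6-tetramethylpiperidin-4-yl)oxy group on the carbonyl carbon gives way to a (3-(methanesulfonamido)propyl)amino group, with no ring and two hydrogen-bond donors in place of one.

With no measured step of this kind in the set, the size and direction of the change cannot be read from the data. The expectation is a small step in this assay, not clearly beyond the scatter, leaning towards a weaker inhibitor, as a 1.5-fold higher number from compound 1 to compound 3 (0.19 log units; within the scatter) expresses. Compound 3 is therefore estimated at 2000 nM, with a range from 500 nM to 8000 nM.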

Compound 3, half-maximal inhibitory concentration: 10400 nM
For compound 3 the middle estimate is 5.2-fold (0.72 log units) below the measured one; measured number above the stated range.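

At this position, on a carbonyl carbon whose other neighbour is a saturated chain carbon, the end of the side chain is not indifferent in this assay: (3-(methanesulfonamido)propyl)amino in place of (2,2,6,6-tetramethylpiperidin-4-yl)oxy gives an 8.0-fold higher number from compound 1 to compound 3 (0.90 log units; beyond the scatter). Among the compounds shown here, this is the first readable step, and it places the open chain with no ring on the weaker side of the ring-bearing ester group. The exchange alters the ring, the donor count and the atom joined to the carbonyl carbon all at once, and nothing measured separates these changes or explains the step.

Steps to compound 2 cannot be read, and one pair gives no trend along the side chain. Open, going by these compounds, is whether the amide of 2,2,6,6-tetramethylpiperidin-4-amine, which keeps the ring and changes only the linking atom, stays close to compound 1, and whether a plain propyl amide or a chain ending in a carboxylic acid sits nearer to compound 1 or to compound 3.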